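The compounds below may be only part of what the source reports. "The series", "measured", "known", "first", "only" and "open" are said of these compounds alone.

Working notes on the series in a functional assay with Oryctolagus cuniculus as the target; a higher number here means a weaker inhibitor, a lower number a stronger inhibitor.

Compound 1, `COc1ccc(-c2nc(/N=C(\N)N(C)C)sc2-c2ccc(OC)cc2)cc1`, gives 37 nM in this assay. Of the two numbers in hand it is the lowest; the nearest is compound 2, `C/N=C(/NC)Nc1nc(-c2ccc(OC)cc2)c(-c2ccc(OC)cc2)s1`, which gives 970 nM, so that a 26-fold higher number from compound 1 to compound 2 (1.42 log units; beyond the scatter). Compound 3, `COc1ccc(-c2nc(CN)sc2-c2ccc(OC)cc2)cc1`, is reported only as a limit of this assay, > 100 nM. The step of an at least 2.7-fold higher number from compound 1 to compound 3 (0.43 log units; beyond the scatter) is therefore read only as a lower bound, and the pair from compound 2 to compound 3 shows nothing that the limit does not hide; see (the limit of > 100 nM in this assay, at which 1 of the 3 values shown sits).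

Compound 4, `CCOC(=O)/C=C/c1nc(-c2ccc(OC)cc2)c(-c2ccc(OC)cc2)s1`, is not yet measured. Its change from compound 1 is a group of 7 heavy atoms (5 carbon, 2 oxygen; no ring) in place of a group of 6 heavy atoms (3 carbon, 3 nitrogen; no ring), on an aromatic carbon. The two steps that bear on it both replace the same group on the same aromatic carbon of the shared core, and both raise the number, one by a large step, the other by at least a modest one. A higher number is therefore expected for compound 4, probably by a large step, a 22-fold higher number from compound 1 to compound 4 (1.33 log units; beyond the scatter). The estimate for compound 4 in this assay is 800 nM, with a range from 150 nM to 5000 nM.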

Compound 4, half-maximal inhibitory concentration: 20 nM
Estimate against measurement, compound 4: 40-fold (1.60 log units) above; the measured number lies below the stated range.
By their numbers in this assay, from the lowest: compounds 4 and 1 (each within the scatter of the next); then compound 2.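

In this assay, the aromatic carbon next to the ring nitrogen and next to the ring sulfur tolerates a replacement of the group of compound 1 that does not raise the number: 2-(ethoxycarbonyl)ethenyl, with no nitrogen and 0 hydrogen-bond donors, gives a 1.9-fold lower number from compound 1 to compound 4 (0.27 log units; within the scatter). A low number at this position is therefore not confined to a group with three nitrogens, and the position also spans a 49-fold lower number from compound 2 to compound 4 (1.69 log units; beyond the scatter). Compound 3 is reported only as a limit of this assay, so an at least 5.0-fold lower number from compound 3 to compound 4 (0.69 log units; beyond the scatter) is read only as a bound: the limit of > 100 nM in this assay, at which 1 of the 4 values shown sits.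

The compounds shown leave open whether the ethyl ester or the double bond matters more at this position. A carboxylic acid, an amide or a saturated propanoate chain in place of 2-(ethoxycarbonyl)ethenyl would bear on that.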